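The source may report more compounds than this note shows. Statements on the series, on what has been measured and on what is new or still open speak of the compounds shown alone.

Working notes on the series, read in a functional assay on A-375 cells (Homo sapiens) for antiproliferative activity, read by trypan blue exclusion and crystal violet staining, with a stated time of 72 h; on this read-out higher numbers stand for weaker inhibition and lower numbers for stronger inhibition. Compound 1 `COc1ccc(C(NC(C)=O)c2cc(Cl)c3cccnc3c2O)cc1OC` gives 110 nM and compound 2 `CCCC(=O)NC(c1ccc(C)cc1)c1cc(Cl)c2cccnc2c1O` gives 120 nM. These two numbers lie within the scatter of each other, so compound 2 stands level with compound 1 and neither ranks ahead. Compound 3 `CCCCC(=O)NCc1ccc2cccnc2c1O` offers no number to set against them, its entry reading "nd" (no result reported), so the measured picture consists of just this one level pair.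

Compound 4 `CCCC(=O)NC(c1ccc(Cl)cc1)c1cc(Cl)c2cccnc2c1O` departs from compound 2 at a single place: chloro in place of methyl on an aromatic carbon. In words, this is chloro in place of methyl on an aromatic carbon, para to a large group; cut one bond further out, the same difference reads 4-methylphenyl to 4-chlorophenyl.

Within the data shown here, no measured pair shows this change on its own, so its size in this assay cannot be read from the data. The expectation therefore starts from compound 2 at 120 nM and allows for no step beyond the scatter, with no firm direction. Expected size: a 1.1-fold lower number from compound 2 to compound 4 (0.04 log units; within the scatter), an estimate that stays within the scatter. For compound 4 the expected value is 110 nM, with an estimated range of 45 nM to 280 nM.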

Compound 4, half-maximal inhibitory concentration: 120 nM
For compound 4 the middle estimate is 1.1-fold (0.04 log units) below the measured one, within the range that was stated.
By their numbers in this assay, from the lowest: compounds 1, 2 and 4 (each within the scatter of the next).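

Chloro in place of methyl on an aromatic carbon, para to a large group, gives no change at the digits printed from compound 2 to compound 4 (within the scatter) in this assay. Among these compounds, this is the first step that isolates one place, and it shows that, on this background, the 4-methylphenyl and 4-chlorophenyl forms cannot be told apart on this read-out. No measured property bears on this result, so the data offer no account of why the two groups read alike.

The compounds shown leave open how this position responds to a group of a different kind, such as an amine or a carboxylic acid in the same place, since methyl and chloro are the only two groups compared there on a single change. From the compounds shown here alone, whether the swap from 4-methylphenyl to 4-chlorophenyl also reads the same alongside a longer chain on the amide remains open too, as this single pair shows the change on one background only.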